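The source may report more compounds than this note shows. Statements on the series, on what has been measured and on what is new or still open speak of the compounds shown alone.

Working notes on the sulfonamide series. All compounds share one core and differ only in the group on the sulfonyl sulfur. Compound 1 `Nc1ncnc(N2CC[C@@]3(CCCN(C[C@H](O)CNS(=O)(=O)c4ccccc4Br)C3)C2)c1C1CC1` carries 2-bromophenyl there, and in an assay on isolated protein for inhibition of RAC-alpha serine/threonine-protein kinase (Homo sapiens) (on this read-out lower numbers stand for stronger inhibition and higher numbers for weaker inhibition), compound 1 gives 17 nM. Going by the values given here, compound 2 `Cc1ccncc1S(=O)(=O)NC[C@@H](O)CN1CCC[C@@]2(CCN(c3ncnc(N)c3C3CC3)C2)C1` carries 4-methylpyridin-3-yl, and in this assay compound 2 gives 1100 nM, the highest of the two numbers so far; the one step between them is a 65-fold higher number from compound 1 to compound 2 (1.81 log units; beyond the scatter).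

Compound 3 `Cc1noc(C)c1S(=O)(=O)NC[C@@H](O)CN1CCC[C@@]2(CCN(c3ncnc(N)c3C3CC3)C2)C1` is the next member; it differs from compound 2 by 3,5-dimethyl-1,2-oxazol-4-yl in place of 4-methylpyridin-3-yl on a sulfonyl sulfur. Among the compounds with values here, the only measured step that bears on this place is the one from compound 1 to compound 2, and it shows that the group on the sulfonyl sulfur can move the number by a large amount. Neither of the two groups in the present change is 2-bromophenyl, so that step gives no direction for it, only a sense of how wide the swing can be. On this basis the number for compound 3 is expected to stay close to compound 2, with a 1.4-fold lower number from compound 2 to compound 3 (0.14 log units; within the scatter) as the estimated step and broad uncertainty either way. For compound 3 the estimate in this assay is 800 nM, within 150 nM to 4000 nM.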

Compound 3, half-maximal inhibitory concentration: 3 nM
Compound 3: the middle estimate sits 270-fold (2.43 log units) above what was measured; the measured number lies below the stated range.
By their numbers in this assay, from the lowest: compound 3; then compound 1; then compound 2.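

In this assay, the group on the sulfonyl sulfur proves far more sensitive than its size alone suggests: a 370-fold lower number from compound 2 to compound 3 (2.56 log units; beyond the scatter), although 4-methylpyridin-3-yl and 3,5-dimethyl-1,2-oxazol-4-yl both have 7 heavy atoms, no hydrogen-bond donors and no net charge. The further step, a 5.7-fold lower number from compound 1 to compound 3 (0.75 log units; beyond the scatter), shows that 2-bromophenyl is not needed for the low numbers in this small set, and that the rise seen with 4-methylpyridin-3-yl does not extend to every aromatic ring bearing hetero atoms, as 3,5-dimethyl-1,2-oxazol-4-yl goes against any such reading. Nothing available explains this large difference between two groups of equal heavy-atom count.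

The compounds shown leave open how far the low number of compound 3 depends on the two methyl groups rather than on the 1,2-oxazol-4-yl ring itself, since a 1,2-oxazol-4-yl without methyl groups does not appear among them. They also leave open how the number would respond to an unsubstituted phenyl or to a non-aromatic group such as cyclopropyl on the sulfonyl sulfur.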